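The source may report more compounds than this note shows. Statements on the series, on what has been measured and on what is new or still open speak of the compounds shown alone.

In a functional assay on A549 cells (Homo sapiens) for cytotoxicity, read by MTT assay, with a stated time of 48 h (on this read-out higher numbers stand for weaker inhibition and lower numbers for stronger inhibition), compound 1 `Cc1ccc(Cn2cc(COc3ccc4c(=O)ccoc4c3)nn2)cc1` gives 50700 nM. Compound 2 `Cc1ccccc1Cn1cc(COc2ccc3c(=O)ccoc3c2)nn1` reaches only the limit of this assay, > 100000 nM. Compound 3 `O=c1ccoc2cc(OCc3cn(Cc4ccc(Br)cc4)nn3)ccc12` also stands at the limit of this assay, > 100000 nM; this is the limit of > 100000 nM in this assay, at which 2 of the 3 values shown sit. Compound 4 `N#Cc1ccc(Cn2cc(COc3ccc4c(=O)ccoc4c3)nn2)cc1` differs from compound 3 by cyano in place of bromo on an aromatic carbon. For the measured compounds named here, no measured pair swaps bromo for cyano, so no step speaks to this change directly. The nearest measured steps, an at least 1.9-fold higher number from compound 1 to compound 3 (0.29 log units; that floor lies within the scatter) and an at least 1.9-fold higher number from compound 1 to compound 2 (0.29 log units; that floor lies within the scatter), are both floors lying within the scatter, while a step that the two limits leave unreadable from compound 2 to compound 3 cannot be read. The step of a number no higher from compound 3 to compound 4 (the limit leaves the size open) implied by this estimate is expected to stay within the scatter. Compound 4 is therefore estimated at 100000 nM, in a range from 35000 nM to 300000 nM, and is expected most likely to return a limit again.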

Compound 4, half-maximal inhibitory concentration: > 100000 nM
Compound 4: no number, only a limit; the forecaster's own chance of this, stated with the estimate: 60%; the middle value sits exactly at the limit.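

With cyano on this aromatic carbon, para to a large group, compound 4 also gives only a limit, not a number, as the bromo of compound 3 did, and the limit now holds most of the series: the limit of > 100000 nM in this assay, at which 3 of the 4 values shown sit.

Cyano in place of methyl gives an at least 1.9-fold higher number from compound 1 to compound 4 (0.29 log units; that floor lies within the scatter). The steps to compound 4 from compound 2 and from compound 3 join two limits and cannot be read.

On these data alone, how far compound 2, compound 3 and compound 4 lie past the limit stays open, so they cannot be ranked. As far as these compounds go, whether an amine or a carboxylic acid here would give a measurable value in this assay is also open.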